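The compounds below may be only part of what the source reports. "The series", "measured", "known", "first", "only" and "open" are said of these compounds alone.

Measured compounds:
- compound 1, `Cc1cc(NC(=O)Cn2nnc(-c3ccccc3)n2)n(C2CCC(F)(F)CC2)n1`: 84 nM
- compound 2, `Cc1cc(NC(=O)Cn2nnc(-c3ccccc3)n2)n(C2CCC(C)(C)CC2)n1`: > 221 nM
- compound 3, `Cc1cc(NC(=O)Cn2nnc(-c3ccccc3)n2)n(CC2CCCCC2)n1`: 176 nM

The three compounds share one core and differ only in the group on the aromatic nitrogen. In an assay on HEK293 cells for activation of Kir3.1/Kir3.2 (Homo sapiens), read by thallium flux (a lower number here means that less compound is needed, a higher number that more compound is needed for the effect), compound 1 gives 84 nM. Compound 2 gives only a limit of this assay, > 221 nM, as noted in the limit of > 221 nM in this assay, at which 1 of the 3 values shown sits. Compound 3 gives 176 nM, the highest of the two numbers shown; the step of a 2.1-fold higher number from compound 1 to compound 3 (0.32 log units; beyond the scatter) lies beyond the scatter, while the step of an at least 1.2-fold lower number from compound 2 to compound 3 (0.09 log units; that floor lies within the scatter) does not. The step of an at least 2.6-fold higher number from compound 1 to compound 2 (0.42 log units; beyond the scatter) is at least modest.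

Compound 4, `Cc1cc(NC(=O)Cn2nnc(-c3ccccc3)n2)n(-c2ccccc2)n1`, carries phenyl in place of cyclohexylmethyl on an aromatic nitrogen. Every measured step swaps one saturated group for another; none brings in an aromatic ring, so the measured steps bear only loosely on this change. They were all modest or within the scatter, and a step of similar size, in either direction, is expected here. The estimated step is a 1.4-fold higher number from compound 3 to compound 4 (0.15 log units; within the scatter). Compound 4 is expected to give 250 nM in this assay, between 80 nM and 800 nM.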

Compound 4, half-maximal effective concentration: 3020 nM
Estimate against measurement, compound 4: 12-fold (1.08 log units) below; measured number above the stated range.
By their numbers in this assay, from the lowest: compound 1; then compound 3; then compound 4.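

Replacing the saturated group on the aromatic nitrogen with phenyl changes the result far more than any exchange among the saturated groups shown: in this assay, there is a 17-fold higher number from compound 3 to compound 4 (1.23 log units; beyond the scatter), and also a 36-fold higher number from compound 1 to compound 4 (1.56 log units; beyond the scatter). This position therefore accommodates the saturated groups shown with much smaller differences, while this change to an aromatic ring carries a large cost in the amount of compound needed. Compound 2 gives only a limit, so its step to compound 4 cannot be read: the limit of > 221 nM in this assay, at which 1 of the 4 values shown sits. Nothing measured here gives a cause for the large steps to phenyl.

The compounds shown leave open whether a benzyl group, which would keep a carbon link to an aromatic ring, would behave more like cyclohexylmethyl or like phenyl. They also leave open how a pyridine ring on this nitrogen would compare.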